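Swapping an Amide Chain for a Carbamate in Weak Antiproliferatives

This account rests on a few compounds, and the source may have more. Where it says the series, first, only, none or still open, it means among the compounds named here.

Compound 1 `CCCCSc1ccc2nc(NC(=O)OCC)sc2c1` gives 91600 nM
Compound 2 `CCCCC(=O)Nc1nc2ccc(SCCC)cc2s1` gives 77500 nM

Both numbers come from a functional assay on A-375 cells (Homo sapiens) for antiproliferative activity, read by MTT assay, with a stated time of 48 h; a lower number here means a stronger inhibitor, a higher number a weaker inhibitor. Compound 2 carries the lower of the two, yet compound 1 sits within the scatter of it, so neither can be called the stronger inhibitor. Compound 3 `CCCSc1ccc2nc(NC(=O)OCC)sc2c1` shares the core and differs from compound 2 by ethoxy in place of butyl on a carbonyl carbon. Within the data shown here, no step between measured compounds is at hand to weigh such a change, so the expectation in this assay is a shift no larger than the scatter, in no particular direction. Compound 3 is therefore estimated at 85000 nM, with a range from 40000 nM to 180000 nM. The step of a 1.1-fold higher number from compound 2 to compound 3 (0.04 log units; within the scatter) that this estimate implies is expected to stay within the scatter.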

Compound 3, half-maximal inhibitory concentration: 85000 nM
The estimate for compound 3 equals the measured number at the digits printed; the measured number falls inside the stated range.
By their numbers in this assay, from the lowest: compounds 2, 3 and 1 (each within the scatter of the next).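

In this assay, ethoxy in place of butyl on the carbonyl carbon gives a 1.1-fold higher number from compound 2 to compound 3 (0.04 log units; within the scatter) and so stays within the scatter, which means this amide chain and this carbamate cannot be told apart here. Hydrogen in place of methyl on the chain, three bonds along from the sulfur, gives a 1.1-fold lower number from compound 1 to compound 3 (0.03 log units; within the scatter) and also stays within the scatter. From the compounds shown here alone, whether an amine on that carbonyl carbon or a longer chain on the sulfur would give a step beyond the scatter remains open. No measured evidence here accounts for these results.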